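A few compounds are considered here, and "the series" means these few. Any claim that something is new, unique, unknown or untested is made for them only; others in the source may bear on it.

Compound 3 `O=C([C@@H]1CCCN(S(=O)(=O)c2ccc(S(=O)(=O)C3CC3)cc2)C1)N1CCC(F)(F)CC1` gives 129 nM in a functional assay on BXPC-3 cells (Homo sapiens) for inhibition, read by MTT assay, with a stated time of 7 days (a lower number here means a stronger inhibitor, a higher number a weaker inhibitor), the second highest of three numbers: compound 2 `CC(C)S(=O)(=O)c1ccc(S(=O)(=O)N2CCC[C@@H](C(=O)N3CCC(F)(F)CC3)C2)cc1` gives 50 nM, and compound 1 `O=C([C@@H]1CCCN(S(=O)(=O)c2ccc(S(=O)(=O)C3COC3)cc2)C1)N1CCC(F)(F)CC1` gives 361 nM. Compound 4 `CCN(CC)S(=O)(=O)c1ccc(S(=O)(=O)N2CCC[C@@H](C(=O)N3CCC(F)(F)CC3)C2)cc1` carries diethylamino in place of cyclopropyl on a sulfonyl sulfur. Within the data shown here, no measured step puts a nitrogen-linked group on that sulfonyl sulfur; the nearest comparisons are a 2.6-fold higher number from compound 2 to compound 3 (0.41 log units; beyond the scatter) and a 2.8-fold lower number from compound 1 to compound 3 (0.45 log units; beyond the scatter), with a 7.2-fold lower number from compound 1 to compound 2 (0.86 log units; beyond the scatter) spanning both, so groups on this sulfur have so far moved the number by modest amounts in either direction. An acyclic diethylamino group is expected to land nearer compound 2 than compound 1. Compound 4 is therefore estimated at 90 nM, with a range of 30 nM to 300 nM. That expectation corresponds to a 1.4-fold lower number from compound 3 to compound 4 (0.16 log units; within the scatter).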

Compound 4, half-maximal inhibitory concentration: 120 nM
Compound 4: middle estimate off by 1.3-fold (0.12 log units), on the low side; the measured number falls inside the stated range.
By their numbers in this assay, from the lowest: compound 2; then compounds 4 and 3 (each within the scatter of the next); then compound 1.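

A nitrogen-linked group on this sulfonyl sulfur keeps the number in the range of the carbon-linked groups: diethylamino and cyclopropyl cannot be told apart (a 1.1-fold lower number from compound 3 to compound 4 (0.03 log units; within the scatter)). Diethylamino also falls on the same side as cyclopropyl against the other two groups, with isopropyl still ahead (a 2.4-fold higher number from compound 2 to compound 4 (0.38 log units; beyond the scatter)) and oxetan-3-yl still behind (a 3.0-fold lower number from compound 1 to compound 4 (0.48 log units; beyond the scatter)). No measurement at hand accounts for these steps.

Open, as far as these compounds go, is whether a cyclic amine such as morpholine or pyrrolidine on this sulfur, or a smaller dimethylamino group, would follow diethylamino or reach the number of compound 2.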